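Toward a Basic Side Chain on the Ketone

The source may hold more compounds than are shown below. What is called first, only, known or untested is meant among the compounds shown, and "the series" means these compounds.

Compound 1 `OB1OCc2ccc(-n3cc(Sc4ccc(Cl)c(Cl)c4)c4ccccc43)cc21` in an ADME assay on L929 cells (Mus musculus) for cytotoxicity, read by resazurin assay, with a stated time of 72 h (on this read-out higher numbers stand for weaker inhibition and lower numbers for stronger inhibition), gives > 10 ug/mL, a limit of the assay.
Compound 2 `OB1OCc2ccc(-n3cc(Sc4ccc(Cl)cc4)c4ccccc43)cc21` in this assay gives > 10 ug/mL, also a limit.
Compound 3 `Cc1ccccc1C(=O)c1ccn(-c2ccc3c(c2)B(O)OC3)c1` in this assay gives > 10 ug/mL, again a limit.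

Compound 3 therefore stands at the limit of > 10 ug/mL in this assay, at which 3 of the 3 values shown sit, with no number of its own. Compound 4 `NCCCC(=O)c1ccn(-c2ccc3c(c2)B(O)OC3)c1` differs from it by one change (3-aminopropyl in place of 2-methylphenyl on a carbonyl carbon).

Within the data shown here, the only measured step, a step that the two limits leave unreadable from compound 1 to compound 2, cannot be sized, so no measured step bears on this change, and the limits give no readable step in this assay to expect. Compound 4 is estimated at 30 ug/mL, between 10 ug/mL and 100 ug/mL, the step that the limit leaves unreadable from compound 3 to compound 4 being expected to fall within the scatter.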

Compound 4, half-maximal inhibitory concentration: > 10 ug/mL
Compound 4: no number, only a limit; the forecaster's own chance of this, stated with the estimate: 85%; the middle value lies beyond the limit too.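

In this assay compound 3 and compound 4 each give only a limit, so no step can be read between them. Still open is whether any compound shown differs from another, as all rest on one value: the limit of > 10 ug/mL in this assay, at which 4 of the 4 values shown sit.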